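The compounds below may be only part of what the source reports. "The series", "measured", "known", "first", "only" and "open" are said of these compounds alone.

Of the compounds shown here, two built on a shared core have so far been tested in a functional assay on SW480 cells (Homo sapiens) for cytotoxicity, read by MTT assay, with a stated time of 24 h; on this read-out lower numbers stand for stronger inhibition and higher numbers for weaker inhibition. Compound 1, `C=CC1=C(C(=O)O)C(c2ccc(OC)cc2)OC1`, carries a carboxylic acid on the core. In this assay compound 1 gives > 100000 nM, which is a limit of the assay rather than a measured number. Compound 2, `C=CC1=C(C(=O)NCCC)C(c2ccc(OC)c(OC)c2)OC1`, carries a propyl amide in that position. In this assay compound 2 gives > 100000 nM, again a limit and not a number. Compound 2 therefore stands where both known values stand: the limit of > 100000 nM in this assay, at which 2 of the 2 values shown sit. Compound 3, `C=CC1=C(C(=O)O)C(c2ccc(OC)c(OC)c2)OC1`, has not yet been measured. It differs from compound 2 by hydroxy in place of propylamino on a carbonyl carbon, which gives it the same acid as compound 1. Within the data shown here, no step between measured compounds is known here, so the step expected is none beyond the scatter, a step that the limit leaves unreadable from compound 2 to compound 3. Compound 3 is estimated to sit at 200000 nM, within a range of 90000 nM to 500000 nM.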

Compound 3, half-maximal inhibitory concentration: > 100000 nM
Compound 3: no number, only a limit; the forecaster's own chance of this, stated with the estimate: 85%; the middle value is on the limit's open side.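

Compound 3 also gives only a limit of the assay, not a number, so no step from compound 1 or compound 2 to compound 3 can be read: the limit of > 100000 nM in this assay, at which 3 of the 3 values shown sit.

The compounds shown leave open what either change, hydroxy in place of propylamino or methoxy in place of hydrogen, does to cytotoxicity.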